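A ring swap at the end of a short series

The source may report more compounds than this note shows. Statements on the series, on what has been measured and on what is new or still open speak of the compounds shown alone.

Compound 1 `Cc1ncc([N+](=O)[O-])n1CCSc1nnc(-c2ccccc2Cl)o1` gives 22500 nM
Compound 2 `Cc1ncc([N+](=O)[O-])n1CCSc1nnc(-c2ccccc2O)o1` gives 28300 nM

Both values come from a functional assay on MCF7 cells (Homo sapiens) for cytotoxicity, read by MTT assay, with a stated time of 48 h (on this read-out higher numbers stand for weaker inhibition and lower numbers for stronger inhibition), where compound 2 stands at 28300 nM and lies within the scatter of compound 1. Among the measured compounds shown here, the only measured step is a 1.3-fold higher number from compound 1 to compound 2 (0.10 log units; within the scatter) with hydroxy in place of chloro on an aromatic carbon.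

Compound 3 `Cc1ncc([N+](=O)[O-])n1CCSc1nnc(-c2ccc(N)nc2)o1` has not yet been measured. Its difference from compound 2 is 6-aminopyridin-3-yl in place of 2-hydroxyphenyl on an aromatic carbon with 6-aminopyridin-3-yl in place of 2-hydroxyphenyl on an aromatic carbon of a five-membered aromatic ring with 2 nitrogen and 1 oxygen. For the measured compounds named here, no measured pair shows what exchanging the whole six-membered aromatic ring does, so the single step is only a weak guide. Going by a 1.3-fold higher number from compound 1 to compound 2 (0.10 log units; within the scatter) alone, a step beyond the scatter in this assay is not expected, and the data favour no direction. The expected step is a 1.1-fold lower number from compound 2 to compound 3 (0.05 log units; within the scatter) by this estimate. Compound 3 is estimated at 25000 nM with 9000 nM to 70000 nM as the expected range.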

Compound 3, half-maximal inhibitory concentration: 26800 nM
Estimate against measurement, compound 3: 1.1-fold (0.03 log units) below; the range from low to high includes it.
By their numbers in this assay, from the lowest: compounds 1, 3 and 2 (each within the scatter of the next).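

The exchange of the whole six-membered aromatic ring, on an aromatic carbon of a five-membered aromatic ring with 2 nitrogen and 1 oxygen, gives in this assay a 1.1-fold lower number from compound 2 to compound 3 (0.02 log units; within the scatter), and measured against the chlorinated member of the series it gives a 1.2-fold higher number from compound 1 to compound 3 (0.08 log units; within the scatter). The earlier pair showed only that chloro and hydroxy read alike on a ring of carbon only, whereas this result extends that to a ring with a hetero atom carrying an amine: 2-chlorophenyl, 2-hydroxyphenyl and 6-aminopyridin-3-yl cannot be told apart at this position in this cytotoxicity read-out. No accompanying data bear on why these numbers stay together.

From the compounds shown here alone, all three compounds still carry a six-membered aromatic ring at this place, so it remains open whether a smaller group such as methyl, a saturated ring such as cyclohexyl or a carboxylic acid on the ring would move the number beyond the scatter. The rest of the core of compound 1 is shared by all three, which also leaves open what a longer chain in place of the two-carbon link to sulfur would do.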